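The compounds below may be only part of what the source reports. "The series", "measured", "known", "first", "only" and "open" are said of these compounds alone.

Measured in a functional assay on DWD cells (Homo sapiens) for inhibition, read by sulforhodamine B assay; a lower number here means a stronger inhibitor of growth, a higher number a weaker inhibitor of growth:
compound 1 `c1ccc(-c2ccc(-c3ccc(-c4nc5ccccc5[nH]4)cc3)cc2)cc1` gives 100000 nM
compound 2 `Fc1ccc(-c2ccc(-c3ccc(-c4nc5ccccc5[nH]4)cc3)cc2)cc1` gives 35600 nM
compound 3 `CN(C)c1ccc(-c2ccc(-c3ccc(-c4nc5ccccc5[nH]4)cc3)cc2)cc1` gives 100000 nM

Among these three, compound 2 holds the lowest number (35600 nM) and is the strongest inhibitor of growth of the set, with its steps to both others beyond the scatter. Compound 4 `Oc1cccc2[nH]c(-c3ccc(-c4ccc(-c5ccc(F)cc5)cc4)cc3)nc12` keeps compound 2 whole except at one place: hydroxy in place of hydrogen on an aromatic carbon.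

Within the data shown here, none of the measured steps changes the ring that takes the hydroxy, and none introduces a hydroxy, so they bear on this change only indirectly. Fluoro in place of hydrogen gave a 2.8-fold lower number from compound 1 to compound 2 (0.45 log units; beyond the scatter) and dimethylamino in place of hydrogen gave no change at the digits printed from compound 1 to compound 3 (within the scatter) while dimethylamino in place of fluoro gave a 2.8-fold higher number from compound 2 to compound 3 (0.45 log units; beyond the scatter) and these are the only guide to size. A small step with no firm direction is therefore expected in this assay and the range is kept wide. The expected step is a 1.4-fold lower number from compound 2 to compound 4 (0.15 log units; within the scatter) and it is only an estimate. Compound 4 is estimated at 25000 nM with an expected range from 6000 nM to 100000 nM.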

Compound 4, concentration for 50% growth inhibition: 22200 nM
Estimate against measurement, compound 4: 1.1-fold (0.05 log units) above; measured number inside the range.
By their numbers in this assay, from the lowest: compounds 4 and 2 (each within the scatter of the next); then compounds 1 and 3 (each within the scatter of the next).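

In this assay hydroxy in place of hydrogen on an aromatic carbon of the six-membered aromatic ring of carbon only gives a 1.6-fold lower number from compound 2 to compound 4 (0.21 log units; within the scatter) and so leaves compound 4 and compound 2 indistinguishable in this assay. This is the first change shown on that ring and the first to bring in a hydroxy, and it shows that this position, ortho to a fused ring and meta to a fused ring, takes the group with no step beyond the scatter. No supporting measurement is available to explain this outcome.

What the compounds shown leave open is whether a methoxy, an amine or a carboxylic acid on the same carbon would also stay within the scatter of compound 2. They also leave open whether hydroxy would give a similar step on the core of compound 1, which lacks the fluoro.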